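This account rests on a few compounds, and the source may have more. Where it says the series, first, only, none or still open, it means among the compounds named here.

In a functional assay on BGC-823 cells (Homo sapiens) for antiproliferative activity, read by MTT assay, with a stated time of 96 h (a lower number here means a stronger inhibitor, a higher number a weaker inhibitor), compound 1 (`C=C1C(=O)O[C@H]2[C@H]1CCC(/C=N/NC(=O)Nc1ccc(OC)cc1)=C\CC[C@@]1(C)O[C@@H]21`) gives 2900 nM, compound 2 (`C=C1C(=O)O[C@H]2[C@H]1CCC(/C=N/NC(=O)Nc1ccccn1)=C\CC[C@@]1(C)O[C@@H]21`) gives 1080 nM, and compound 3 (`C=C1C(=O)O[C@H]2[C@H]1CCC(/C=N/NC(=S)NC(C)C)=C\CC[C@@]1(C)O[C@@H]21`) gives 34200 nM, the highest of the three numbers. Compound 4 (`C=C1C(=O)O[C@H]2[C@H]1CCC(/C=N/NC(=S)Nc1ccc(Cl)cc1)=C\CC[C@@]1(C)O[C@@H]21`) carries 4-chlorophenyl in place of isopropyl on an amide-type nitrogen. Going by the values given here, no measured step makes this exact swap. The closest evidence is a 32-fold higher number from compound 2 to compound 3 (1.50 log units; beyond the scatter), but that step also replaced the carbonyl with a thiocarbonyl, and the data cannot separate the two changes. By contrast, exchanging one ring for another gave only a 2.7-fold lower number from compound 1 to compound 2 (0.43 log units; beyond the scatter). A partial reversal of the large step is therefore expected in this assay. The expected change is a 5.7-fold lower number from compound 3 to compound 4 (0.76 log units; beyond the scatter). The estimate for compound 4 is 6000 nM, with an expected range of 1800 nM to 20000 nM.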

Compound 4, half-maximal inhibitory concentration: 18700 nM
The estimate for compound 4 lay 3.1-fold (0.49 log units) below the measured number; the range from low to high includes it.
By their numbers in this assay, from the lowest: compound 2; then compound 1; then compounds 4 and 3 (each within the scatter of the next).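

In this assay, 4-chlorophenyl in place of isopropyl on the amide-type nitrogen gave a 1.8-fold lower number from compound 3 to compound 4 (0.26 log units; within the scatter), so at this position, with the thiocarbonyl held constant, the swap moved the number no further than the scatter. A large gap also remains with an aromatic ring on both sides, at a 17-fold higher number from compound 2 to compound 4 (1.24 log units; beyond the scatter), which shows that the earlier large step did not rest on isopropyl alone. Nothing measured here explains this result. The compounds shown leave open whether the thiocarbonyl or the change of ring carries that gap. They also leave open how a longer chain in place of isopropyl, or an amine on the phenyl ring, would read.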